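From phenyl to 3-methoxyphenyl: cytotoxicity working notes

The source may report more compounds than this note shows. Statements on the series, on what has been measured and on what is new or still open speak of the compounds shown alone.

In an ADME assay on MT4 cells (Homo sapiens) for cytotoxicity, read by MTT assay, with a stated time of 4 days (on this read-out lower numbers stand for higher toxicity in this test and higher numbers for lower toxicity in this test), compound 1 (`COc1cccc(-c2oc3ccc(NC(C)=O)cc3c(=O)c2O)c1`) gives 33300 nM and compound 2 (`COc1c(-c2ccccc2)oc2ccc(NC(C)=O)cc2c1=O`) gives 200000 nM. Compound 2 therefore holds the higher of the two numbers, meaning lower toxicity in this test, and its gap to compound 1 lies beyond the scatter. Compound 3 (`COc1cccc(-c2oc3ccc(NC(C)=O)cc3c(=O)c2OC)c1`) differs from compound 2 by methoxy in place of hydrogen on an aromatic carbon, meta to a large group, which reads as phenyl to 3-methoxyphenyl (methoxy in place of hydrogen on an aromatic carbon). Among the measured compounds shown here, no measured step isolates this change, so the expectation is loose. A small move toward a lower number in this assay is expected, about the size of the scatter, since compound 1 at 33300 nM shows that a lower reading occurs in this series. The estimated step is a 1.8-fold lower number from compound 2 to compound 3 (0.26 log units; within the scatter). For compound 3 the estimated value is 110000 nM, with an expected range of 35000 nM to 250000 nM.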

Compound 3, half-maximal cytotoxic concentration: 369000 nM
Beside the measured number, compound 3's estimate is 3.4-fold (0.53 log units) below it, and the stated range ends below it.
By their numbers in this assay, from the lowest: compound 1; then compounds 2 and 3 (each within the scatter of the next).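

In this assay, methoxy in place of hydrogen on an aromatic carbon gives a 1.8-fold higher number from compound 2 to compound 3 (0.27 log units; within the scatter), so the phenyl to 3-methoxyphenyl change does not separate compound 3 from compound 2. Methyl in place of hydrogen on an oxygen on an aromatic ring gives an 11-fold higher number from compound 1 to compound 3 (1.04 log units; beyond the scatter), a large step, so among these compounds the clear difference in this assay goes with that oxygen's substituent and not with the methoxy on the phenyl ring. No measured evidence here accounts for either step.

Open, from the compounds shown here alone, is whether an amine or a carboxylic acid in place of the methoxy on the phenyl ring would stay within the scatter of compound 3. Also open, going by these compounds, is whether a longer chain, such as ethyl, on the oxygen would read like methyl.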